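The compounds below may be only part of what the source reports. "The series", "measured", "known", "first", "only" and "open" are said of these compounds alone.

Among the compounds with values here, compound 1 `ClCc1ccccc1Cn1cnc2c(Cl)nc(Cl)nc21` is one of two compounds measured in a functional assay on HT-29 cells (Homo sapiens) for cytotoxicity, read by sulforhodamine B assay, with a stated time of 48 h; on this read-out higher numbers stand for weaker inhibition of growth and lower numbers for stronger inhibition of growth. In this assay compound 1 gives 420 nM, the lower of the two numbers. Compound 2 `ClCc1ccc(Cn2cnc3nc(Cl)nc(Cl)c32)cc1` carries the same kind of groups arranged differently, and in this assay compound 2 gives 3540 nM, a number above that of compound 1 by more than the usual scatter.

Compound 3 `Nc1nc(Cl)c2ncn(Cc3ccccc3CCl)c2n1` has not yet been measured. It differs from compound 1 in one place: amino in place of chloro on an aromatic carbon. The group that leaves and the group that enters are both single heavy atoms, but the amino group brings a hydrogen-bond donor and a hydrogen-bond acceptor that the chloro group lacks. The two measured compounds give no guide to such an exchange on the shared core, so the expected step of a 2.9-fold higher number from compound 1 to compound 3 (0.46 log units; beyond the scatter) is taken as a moderate move toward a higher number, only a little beyond the scatter. Compound 3 is expected to give about 1200 nM in this assay, with a likely range from 400 nM to 4000 nM.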

Compound 3, concentration for 50% growth inhibition: 3890 nM
Compound 3: middle estimate off by 3.2-fold (0.51 log units), on the low side, within the range that was stated.
By their numbers in this assay, from the lowest: compound 1; then compounds 2 and 3 (each within the scatter of the next).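

In this assay, amino in place of chloro on this aromatic carbon, between two ring nitrogen atoms, gives a 9.3-fold higher number from compound 1 to compound 3 (0.97 log units; beyond the scatter), so growth is inhibited less strongly. Compounds 1 and 2 differ in how their groups are arranged and could say nothing about this position, whereas this step shows that the group held here makes a clear difference to the read-out. Nothing available here explains why the number rises.

From the compounds shown here alone, it remains open whether the rise comes from removing chloro or from adding amino, and a methoxy or methylamino group at this place would help to separate the two. Going by these compounds, it is also open whether the chloro group meta to this position would respond in the same way to amino.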